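Iodo in place of ethynyl: working notes on the series

The compounds below may be only part of what the source reports. "The series", "measured", "known", "first", "only" and "open" are said of these compounds alone.

Measured in an ADME assay on BJ cells (Homo sapiens), read by MTT assay, with a stated time of 72 h (a higher number here means a weaker inhibitor, a lower number a stronger inhibitor), as follows:
- Compound 1 `Cc1nc(N)c2c(-c3ccco3)cn([C@@H]3O[C@H](CO)[C@@H](O)[C@H]3O)c2n1` gives > 100000 nM as a limit
- Compound 2 `Cc1nc(N)c2c(-c3ccccc3)cn([C@@H]3O[C@H](CO)[C@@H](O)[C@H]3O)c2n1` gives > 100000 nM as a limit
- Compound 3 `C#Cc1cn([C@@H]2O[C@H](CO)[C@@H](O)[C@H]2O)c2nc(C)nc(N)c12` gives > 100000 nM as a limit

Compound 3 has no number on the scale, and its reading is only a limit. Going by the values given here, the series so far shows the limit of > 100000 nM in this assay, at which 3 of the 3 values shown sit, and nothing else. Compound 4 `Cc1nc(N)c2c(I)cn([C@@H]3O[C@H](CO)[C@@H](O)[C@H]3O)c2n1` carries iodo in place of ethynyl on an aromatic carbon and is otherwise unchanged. The relevant exchanges on that carbon are a step that the two limits leave unreadable from compound 1 to compound 2 together with a step that the two limits leave unreadable from compound 1 to compound 3 and a step that the two limits leave unreadable from compound 2 to compound 3 but none of them gives a size or direction. The expected result is a number no higher from compound 3 to compound 4 (the limit leaves the size open) with no direction expected beyond the scatter. The estimate for compound 4 is 100000 nM with an expected range of 30000 nM to 150000 nM in this assay and a report of only a limit is considered likely.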

Compound 4, half-maximal inhibitory concentration: 24600 nM
Compound 4: the middle estimate sits 4.1-fold (0.61 log units) above what was measured; measured number outside the range, below it.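

Among the groups shown on this aromatic carbon, only iodo gives a reading on the scale of this assay, with an at least 4.0-fold lower number from compound 3 to compound 4 (0.60 log units; beyond the scatter), an at least 4.0-fold lower number from compound 2 to compound 4 (0.60 log units; beyond the scatter) and an at least 4.0-fold lower number from compound 1 to compound 4 (0.60 log units; beyond the scatter). These sizes are bounds set by a limit, and the steps among compound 1, compound 2 and compound 3 cannot be read. Compound 4 therefore gives the series its only number, with the rest at the limit: the limit of > 100000 nM in this assay, at which 3 of the 4 values shown sit.

The compounds shown leave open how large the true gaps are. They also leave open whether chloro, bromo or an amine on this carbon would give a reading on the scale.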